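Swapping cyano for methyl on the benzyl ether of compound 2

The compounds below may be only part of what the source reports. "The series", "measured", "known", "first", "only" and "open" are said of these compounds alone.

Compound 2 `CC(C)(N)C(=O)N[C@H](COCc1ccccc1C#N)c1nnnn1CCOC(=O)NCCCCO` gives 1.26 nM in a functional assay on cells for inhibition of growth hormone secretagogue receptor type 1 (Homo sapiens), read by FLIPR and calcium flux (a higher number here means that more compound is needed for the effect, a lower number that less compound is needed), the highest of the two numbers measured; compound 1 `CC(C)(N)C(=O)N[C@H](COCc1cccc(Cl)c1Cl)c1nnnn1CCOC(=O)NCCCCO` gives 0.61 nM, a step of a 2.1-fold higher number from compound 1 to compound 2 (0.32 log units; beyond the scatter). Compound 3 `Cc1ccccc1COC[C@@H](NC(=O)C(C)(C)N)c1nnnn1CCOC(=O)NCCCCO` differs from compound 2 by methyl in place of cyano on an aromatic carbon. Going by the values given here, no measured step changes that same position; the only step touching this ring, from compound 1 to compound 2, was modest. The step from compound 2 to compound 3 is therefore expected to stay within the scatter, a 1.3-fold lower number from compound 2 to compound 3 (0.10 log units; within the scatter). Compound 3 is estimated at 1 nM, within 0.4 nM to 2.5 nM.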

Compound 3, half-maximal effective concentration: 0.51 nM
Compound 3: the middle estimate sits 2.0-fold (0.29 log units) above what was measured; the range from low to high includes it.
By their numbers in this assay, from the lowest: compounds 3 and 1 (each within the scatter of the next); then compound 2.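

Methyl in place of cyano gives a 2.5-fold lower number from compound 2 to compound 3 (0.39 log units; beyond the scatter), so the nitrile is not needed at this position on the ring to keep the number low. The 2-methylphenyl group also stays level with 2,3-dichlorophenyl, at a 1.2-fold lower number from compound 1 to compound 3 (0.08 log units; within the scatter), so one methyl does as well here as the two chlorines. Nothing available explains the gap between methyl and cyano.

As far as these compounds go, it remains open whether a methoxy group, a single fluorine or a longer chain such as ethyl would hold the number as low at this position.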